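The source may hold more compounds than are shown below. What is called first, only, known or untested is meant among the compounds shown, and "the series" means these compounds.

Compound 2 `O=C(O)c1ccc(C(=O)/C(=C\c2ccc(F)c([N+](=O)[O-])c2)S(=O)(=O)Cc2ccc(Br)cc2)cc1` is the starting point here. In a physicochemical assay for solubility (on this read-out higher numbers stand for higher solubility and lower numbers for lower solubility), compound 2 gives < 1000 ug/mL, which is a limit of the assay rather than a number. Compound 1 `O=C(O)c1ccc(C(=O)/C(=C\c2ccc(F)c([N+](=O)[O-])c2)SCc2ccc(Cl)cc2)cc1` also returns a limit: in this assay compound 1 gives < 1000 ug/mL. Compound 3 `O=C(/C(=C\c1ccc(F)c([N+](=O)[O-])c1)SCc1ccc(F)cc1)c1ccc(F)cc1` is the third measured compound, and in this assay compound 3 gives < 1000 ug/mL, again a limit. Among the compounds with values here, the one step between measured compounds, a step that the two limits leave unreadable from compound 1 to compound 2, cannot be read in size because both of its ends sit at the limit of < 1000 ug/mL in this assay, at which 3 of the 3 values shown sit. Compound 4 `O=C(O)c1ccc(C(=O)/C(=C\c2ccc(F)c([N+](=O)[O-])c2)SCc2ccc(F)cc2)cc1` differs from compound 2 by (4-fluorobenzyl)sulfanyl in place of (4-bromobenzyl)sulfonyl on a double-bonded chain carbon bound to a carbonyl carbon and a double-bonded chain carbon. With every measured value a limit, no direction beyond the scatter can be drawn. Compound 4 is therefore expected at 300 ug/mL (from 30 ug/mL to 1000 ug/mL), an estimated step that the limit leaves unreadable from compound 2 to compound 4.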

Compound 4, solubility: < 1000 ug/mL
Compound 4 ended at the assay's limit (the forecaster's own chance of this, stated with the estimate: 85%); the middle value is on the limit's open side.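

Within the data shown here, compound 4 also returns only a limit in this assay, so no step linking it to compound 1, compound 2 or compound 3 can be read: the limit of < 1000 ug/mL in this assay, at which 4 of the 4 values shown sit. The compounds shown leave open what actual number each would give, and whether any of these swaps shifts it.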